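Methyl for hydrogen on a ring oxygen in butenolide styryl compounds

The source may report more compounds than this note shows. Statements on the series, on what has been measured and on what is new or still open speak of the compounds shown alone.

Compound 1, compound 2 and compound 3 share a butenolide core joined through a trans double bond to a substituted aromatic ring, and all three have been measured in a functional assay on 786-0 cells (Homo sapiens) for inhibition, read by sulforhodamine B assay, with a stated time of 48 h; a higher number here means a weaker inhibitor of growth, a lower number a stronger inhibitor of growth. Compound 1 `COc1ccc(/C=C/C2(C)C=CC(=O)O2)c(OC)c1OC` gives 132000 nM, compound 2 `COc1c(O)ccc(/C=C/C2(C)C=CC(=O)O2)c1OC` gives 109000 nM, and compound 3 `CC1(/C=C/c2cccc(O)c2)C=CC(=O)O1` gives 196000 nM. Among the compounds with values here, the only single-point change among them is methyl in place of hydrogen on an oxygen on an aromatic ring, which produced a 1.2-fold higher number from compound 2 to compound 1 (0.08 log units; within the scatter). How compound 3 differs from compound 2 is not broken down here.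

Compound 4 `COc1cccc(/C=C/C2(C)C=CC(=O)O2)c1` has not yet been measured. It stands to compound 3 as compound 1 stands to compound 2, with the same change, (methyl in place of hydrogen on an oxygen on an aromatic ring), at a place described in the same words. On that basis the step expected is a 1.1-fold higher number from compound 3 to compound 4 (0.05 log units; within the scatter), resting on the earlier step from compound 2 to compound 1. Compound 4 is accordingly estimated to give 220000 nM in this assay, with a range from 110000 nM to 450000 nM.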

Compound 4, concentration for total growth inhibition: 70000 nM
Compound 4: middle estimate off by 3.1-fold (0.50 log units), on the high side; the measured number lies below the stated range.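

In this assay, methyl in place of hydrogen on an oxygen on an aromatic ring gave a 2.8-fold lower number from compound 3 to compound 4 (0.45 log units; beyond the scatter) on this core, a different outcome from the one seen on the core of compound 2. The size of this change therefore did not carry from one core to the other: the same change on two cores in this assay, a 1.2-fold higher number (0.08 log units; within the scatter) from compound 2 to compound 1 and a 2.8-fold lower number (0.45 log units; beyond the scatter) from compound 3 to compound 4, 3.4-fold (0.53 log units) apart, beyond the scatter of two such steps. Within the data shown here, with only two pairs, this does not show why the steps differ or how the change would behave on any further core.

The compounds shown leave open whether an ethyl group or a longer chain on that oxygen would follow compound 4. They also leave open what an amine in place of the hydroxy of compound 3 would give.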